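The source may hold more compounds than are shown below. What is called first, only, known or untested is meant among the compounds shown, and "the series" means these compounds.

Compound 1 `CN(C(=O)NC(=O)c1ccc(C(F)(F)F)cc1)c1nc(C(F)(F)F)c(C(=O)N/N=C/c2ccc(C(F)(F)F)cc2)s1` gives only a limit in a functional assay on MCF7 cells (Homo sapiens) for inhibition, read by MTT assay, with a stated time of 72 h (on this read-out higher numbers stand for weaker inhibition and lower numbers for stronger inhibition), at > 100 ug/mL. Its companions are compound 2 `CN(C(=O)NC(=O)c1ccc(C(F)(F)F)cc1)c1nc(C(F)(F)F)c(C(=O)N/N=C/c2cccc(C(F)(F)F)c2)s1`, which in this assay gives 8.95 ug/mL, and compound 3 `CN(C(=O)NC(=O)c1c(F)cccc1F)c1nc(C(F)(F)F)c(C(=O)N/N=C/c2cc(C(F)(F)F)cc(C(F)(F)F)c2)s1`, which gives 6.85 ug/mL. Going by the values given here, the one step measured within this set, 3-(trifluoromethyl)phenyl in place of 4-(trifluoromethyl)phenyl on the carbon with a double bond to nitrogen, brought an at least 11-fold lower number from compound 1 to compound 2 (1.04 log units; beyond the scatter). Compound 4 `CN(C(=O)NC(=O)c1ccccc1F)c1nc(C(F)(F)F)c(C(=O)N/N=C/c2ccc(C(F)(F)F)cc2)s1` differs from compound 1 at another site: 2-fluorophenyl in place of 4-(trifluoromethyl)phenyl on a carbonyl carbon. Among the compounds with values here, no measured step touches the ring carried by that carbonyl carbon, so the set gives no guide to the direction or size of this change. Compound 1 itself sits at the limit (the limit of > 100 ug/mL in this assay, at which 1 of the 3 values shown sits). Compound 4 is therefore expected to give roughly 60 ug/mL, between 15 ug/mL and 150 ug/mL. That expectation corresponds to an expected step of an at least 1.6-fold lower number from compound 1 to compound 4 (0.22 log units; that floor lies within the scatter).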

Compound 4, half-maximal inhibitory concentration: 4.98 ug/mL
Compound 4: middle estimate off by 12-fold (1.08 log units), on the high side, outside the stated range (below it).
By their numbers in this assay, from the lowest: compounds 4, 3 and 2 (each within the scatter of the next). At a limit, above all of these: compound 1.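

Going by these compounds alone, the ring on the carbonyl carbon, which no earlier step touched, turns out to matter: 2-fluorophenyl in place of 4-(trifluoromethyl)phenyl there brought an at least 20-fold lower number from compound 1 to compound 4 (1.30 log units; beyond the scatter) in this assay. A 4-(trifluoromethyl)phenyl on the carbon with a double bond to nitrogen therefore does not by itself hold the number at a limit. The step gives only a floor because compound 1 stands at a limit: the limit of > 100 ug/mL in this assay, at which 1 of the 4 values shown sits.

From the compounds shown here alone, whether the change follows the fluorine entering or the trifluoromethyl leaving remains open. A plain phenyl, or an amine or a carboxylic acid on that ring, would help separate the two.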